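A few compounds are considered here, and "the series" means these few. Any claim that something is new, unique, unknown or untested is made for them only; others in the source may bear on it.

Measured so far in an assay on a protein complex (Cavia porcellus) with sulfonylurea receptors; K-ATP channels (Homo sapiens) as the target; a higher number here means a weaker inhibitor, a lower number a stronger inhibitor:
compound 1 `CC(O)(C(=O)Nc1ccc(S(=O)(=O)N2CCCC2)cc1)C(F)(F)F`, 880 nM
compound 2 `CC(O)(C(=O)Nc1ccc(S(N)(=O)=O)cc1)C(F)(F)F`, 12800 nM
compound 3 `CC(O)(C(=O)Nc1ccc(/C(=N\O)c2ccccc2)cc1)C(F)(F)F`, > 30000 nM, which is a limit of the assay and not a number, as noted under the limit of > 30000 nM in this assay, at which 1 of the 3 values shown sits.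

Compound 1 holds the lowest of the two numbers; the nearest is compound 2, reached by a 15-fold higher number from compound 1 to compound 2 (1.16 log units; beyond the scatter), a large step. Compound 4 `CC(C)CN(CC(C)C)S(=O)(=O)c1ccc(NC(=O)C(C)(O)C(F)(F)F)cc1` differs from compound 1 by diisobutylamino in place of pyrrolidin-1-yl on a sulfonyl sulfur. Going by the values given here, the only measured step touching this position is a 15-fold higher number from compound 1 to compound 2 (1.16 log units; beyond the scatter), which shows the number rising sharply when the sulfonyl nitrogen loses both carbon substituents. Compound 4 keeps a doubly substituted nitrogen there, so no step beyond the scatter is expected, at most a modest lowering: the estimated step is a 1.5-fold lower number from compound 1 to compound 4 (0.17 log units; within the scatter). Compound 4 is therefore estimated at 600 nM in this assay, within 150 nM to 2500 nM.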

Compound 4, half-maximal inhibitory concentration: > 30000 nM
Compound 4 gave a limit, no number; the forecaster's own chance of this, stated with the estimate: 5%; at least 50-fold (1.69 log units) between middle value and limit.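

In this assay compound 4 gives > 30000 nM, which is a limit of the assay and not a number: the limit of > 30000 nM in this assay, at which 2 of the 4 values shown sit. Two carbon substituents on the sulfonyl nitrogen are therefore not enough to keep the number low, as diisobutylamino in place of pyrrolidin-1-yl gives an at least 34-fold higher number from compound 1 to compound 4 (1.53 log units; beyond the scatter). Diisobutylamino also falls behind the plain amino group, with an at least 2.3-fold higher number from compound 2 to compound 4 (0.36 log units; beyond the scatter), so the three groups on this sulfonyl sulfur do not follow substitution alone.

Still open, as far as these compounds go, is whether dimethylamino or piperidin-1-yl would stay near compound 1. From the compounds shown here alone, it is also open whether the ring in pyrrolidin-1-yl or the size of the isobutyl chains sets the step.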